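This account rests on a few compounds, and the source may have more. Where it says the series, first, only, none or still open, it means among the compounds named here.

Working notes on the series. The shared core of compound 1 `CCCCNC(=O)C1C(C(=O)O)[C@@H]2CC[C@H]1O2` carries an amide and a carboxylic acid; compound 2 `CCCCCCCCCCNC(=O)C1C(C(=O)O)[C@@H]2CC[C@H]1O2` and compound 3 `CCc1ccccc1NC(=O)C1C(C(=O)O)[C@@H]2CC[C@H]1O2` keep the same core and differ from it only in the group on the amide nitrogen. In an ADME assay on A2780 cells (Homo sapiens) for cytotoxicity, read by MTT assay, with a stated time of 72 h (on this read-out higher numbers stand for weaker inhibition of growth and lower numbers for stronger inhibition of growth), compound 1 gives 10000 nM, compound 2 gives 10000 nM and compound 3 gives 10000 nM. Among the compounds with values here, the single measured step, no change at the digits printed from compound 1 to compound 2 (within the scatter), shows nothing beyond the scatter. Compound 2 thus stands level with compound 1 and compound 3 at the digits shown, and nothing separates the three.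

Compound 4 `CCCNC(=O)C1C(C(=O)O)[C@@H]2CC[C@H]1O2` is the next member: hydrogen in place of heptyl on a saturated chain carbon, three bonds along the chain from an amide-type nitrogen. Within the data shown here, the only measured step that bears on a change of this kind is no change at the digits printed from compound 1 to compound 2 (within the scatter), and it was flat, so no step beyond the scatter is expected in this assay for compound 4. On that basis compound 4 is estimated at 10000 nM, with a range from 5000 nM to 20000 nM. The step of no change at the digits printed from compound 2 to compound 4 (within the scatter) is accordingly expected to be flat, within the scatter.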

Compound 4, concentration for 50% growth inhibition: 10000 nM
Compound 4: middle estimate and measured number agree at the digits printed, and the stated range covers the measured number.
By their numbers in this assay, from the lowest: compounds 1, 2, 3 and 4 (each within the scatter of the next).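

Two further steps at this place, on a saturated chain carbon three bonds along the chain from an amide-type nitrogen, read flat in this assay: hydrogen in place of heptyl (no change at the digits printed from compound 2 to compound 4 (within the scatter)) and hydrogen in place of methyl (no change at the digits printed from compound 1 to compound 4 (within the scatter)). Where only the hexyl step was available before, the removal of a long and of a short group now reads the same, so chain length separates nothing among compound 1, compound 2 and compound 4. No evidence bears on why these values stay level.

The compounds shown leave open whether any change on the amide nitrogen can shift growth inhibition in this assay. On these data alone, a terminal amine or hydroxyl on the chain, or a methyl ester in place of the carboxylic acid, remains untested by these data.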